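The source may hold more compounds than are shown below. What is called first, only, known or untested is meant among the compounds shown, and "the series" means these compounds.

Measured compounds:
compound 1 `CCOC(=O)N1CCC(N(Cc2cc(Cl)ccc2O)C(=O)N(C)C)CC1`: 25700 nM
compound 2 `CN(C)C(=O)N(Cc1ccc(O)cc1)Cc1ccco1`: 52100 nM
compound 3 `CCOC(=O)N1CCC(N(Cc2ccc(O)cc2)C(=O)N(C)C)CC1`: 48600 nM

All three were tested in a functional assay on KB cells (Homo sapiens) for antiproliferative activity, read by MTT assay, with a stated time of 48 h; a lower number here means a stronger inhibitor, a higher number a weaker inhibitor. Compound 2 sits at the upper end of these numbers: compound 3 lies within the scatter of it, while compound 1 lies beyond the scatter, lower. Compound 4 `CN(C)C(=O)N(Cc1ccc([N+](=O)[O-])cc1)Cc1ccco1` has not yet been measured. It differs from compound 2 by nitro in place of hydroxy on an aromatic carbon. Within the data shown here, the only step between measured compounds, a 1.9-fold higher number from compound 1 to compound 3 (0.28 log units; within the scatter), swaps one whole hydroxyphenyl group for another and keeps a hydroxy throughout; no measured step trades hydroxy for nitro, so nothing here shows what that change does. The measured numbers span a narrow band. The expected step is therefore a 1.0-fold lower number from compound 2 to compound 4 (0.02 log units; within the scatter), small if anything, with wide uncertainty. Compound 4 is estimated at 50000 nM, with a range from 15000 nM to 150000 nM.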

Compound 4, half-maximal inhibitory concentration: 17500 nM
Compound 4: middle estimate off by 2.9-fold (0.46 log units), on the high side; low and high end bracket the measured number.
By their numbers in this assay, from the lowest: compounds 4, 1, 3 and 2 (each within the scatter of the next, the first and the last beyond it).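

Replacing the hydroxy on this aromatic carbon, para to a large group, does change the result in this assay: nitro in place of hydroxy gives a 3.0-fold lower number from compound 2 to compound 4 (0.47 log units; beyond the scatter), a modest step beyond the scatter. The hydroxy is therefore not required for activity in this pair, since the compound without it gives the lower number. Nothing available explains the size or direction of this step. The compounds shown leave open whether an amine or a carboxylic acid on this carbon would also lower the number, and whether the same swap would do so on the core of compound 3.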